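From Methoxy to Furan-2-yl in a Thiourea Pair

The source may hold more compounds than are shown below. What is called first, only, known or untested is meant among the compounds shown, and "the series" means these compounds.

Two thiourea compounds have been tested for how much of them cultured human liver-derived cells tolerate. In an ADME assay on Ava5 cells (Homo sapiens) for cytotoxicity (a higher number here means that more compound is tolerated, a lower number that less compound is tolerated), compound 1 `CCCNC(=S)Nc1cccc(OCCCCCc2ccccc2)c1` gives 32000 nM. Compound 2 `COc1ccc(OCCCCCOc2cccc(NC(N)=S)c2)cc1` reaches only a limit of this assay, > 50000 nM, so its tolerated concentration is known as a bound rather than as a number. That bound is the limit of > 50000 nM in this assay, at which 1 of the 2 values shown sits. Compound 3 `NC(=S)Nc1cccc(OCCCCCOc2ccc(-c3ccco3)cc2)c1` has not yet been measured; it carries furan-2-yl in place of methoxy on an aromatic carbon, in words furan-2-yl in place of methoxy on an aromatic carbon. Going by the values given here, no measured pair in this set differs at a single place, so the size of this step has no measured precedent to lean on. Both measured compounds lie toward the high end of the concentration range tested, meaning the cells tolerate a great deal of either. The step of an at least 1.2-fold lower number from compound 2 to compound 3 (0.09 log units; that floor lies within the scatter) is expected to be small, at most a modest move toward less tolerated, and possibly none beyond the scatter. Compound 3 is therefore estimated to give about 40000 nM, within 15000 nM to 100000 nM.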

Compound 3, half-maximal cytotoxic concentration: 11000 nM
The estimate for compound 3 lay 3.6-fold (0.56 log units) above the measured number; the whole stated range lies above it.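

Replacing methoxy with furan-2-yl on an aromatic carbon para to a large group gives, in this assay, an at least 4.5-fold lower number from compound 2 to compound 3 (0.65 log units; beyond the scatter). Going by these compounds alone, this is the first change in the set confined to a single place, and it shows that the group at this position can move the result toward less compound being tolerated, so this position is not indifferent to what sits there. The full size of the step remains unknown, and it could be larger than this floor, because compound 2 stands at a limit of the assay rather than at an exact number: the limit of > 50000 nM in this assay, at which 1 of the 3 values shown sits.

As far as these compounds go, one exchange cannot separate the effect of having a five-membered aromatic ring here from that of simply having a larger group, so it remains open whether a thiophen-2-yl group or an ethoxy group at the same place would lower the number as far. Within the data shown here, compound 1 differs from compound 3 in more than one place, which leaves this single step as the only comparison available and gives no sign of whether it would hold on another core.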